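Replacing 2-chlorophenyl with 3-bromophenyl in compound 3

The source may report more compounds than this note shows. Statements on the series, on what has been measured and on what is new or still open speak of the compounds shown alone.

Measured in a functional assay on MDA-MB-231 cells (Homo sapiens) for antiproliferative activity, read by MTT assay, with a stated time of 72 h; on this read-out higher numbers stand for weaker inhibition and lower numbers for stronger inhibition:
- Compound 1 `NC1=NC2(CCSCC2)N(OCCCOc2ccc(Br)cc2)C(N)=N1` gives 440 nM
- Compound 2 `NC1=NC2(CCSCC2)N(OCCCOc2cc(Cl)c(Cl)cc2Cl)C(N)=N1` gives 110 nM
- Compound 3 `NC1=NC2(CCSCC2)N(OCCCOc2ccccc2Cl)C(N)=N1` gives 80 nM

Compound 3 stands together with compound 2 at the low end of these numbers, as there is a 1.4-fold lower number from compound 2 to compound 3 (0.14 log units; within the scatter). Compound 1 lies clearly apart, with a 5.5-fold lower number from compound 1 to compound 3 (0.74 log units; beyond the scatter) and a 4.0-fold lower number from compound 1 to compound 2 (0.60 log units; beyond the scatter).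

Compound 4 `NC1=NC2(CCSCC2)N(OCCCOc2cccc(Br)c2)C(N)=N1` has not yet been measured in this assay. It differs from compound 3 at one place: 3-bromophenyl in place of 2-chlorophenyl on an oxygen on a saturated carbon, with 3-bromophenyl in place of 2-chlorophenyl on an oxygen on a saturated carbon. Among the measured compounds shown here, no measured compound carries this exact group. For the measured compounds named here, the closest comparison is compound 1, the only measured bromophenyl compound, at 440 nM. Compound 2 shows that a different chlorinated phenyl can stay within the scatter of compound 3. A modest rise is therefore expected, smaller than the gap separating compound 1 from compound 3.

The step expected is a 2.5-fold higher number from compound 3 to compound 4 (0.40 log units; beyond the scatter). For compound 4 the estimated value is 200 nM, with an expected range from 70 nM to 550 nM.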

Compound 4, half-maximal inhibitory concentration: 60 nM
The estimate for compound 4 lay 3.3-fold (0.52 log units) above the measured number, outside the stated range (below it).
By their numbers in this assay, from the lowest: compounds 4, 3 and 2 (each within the scatter of the next); then compound 1.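

In this assay, a bromine on the phenyl ring does not by itself bring the higher number seen for compound 1: 3-bromophenyl in place of 2-chlorophenyl gives a 1.3-fold lower number from compound 3 to compound 4 (0.12 log units; within the scatter), and 3-bromophenyl in place of 2,4,5-trichlorophenyl gives a 1.8-fold lower number from compound 2 to compound 4 (0.26 log units; within the scatter), so compounds 2, 3 and 4 stand together. The two bromophenyl compounds do separate, with 3-bromophenyl in place of 4-bromophenyl giving a 7.3-fold lower number from compound 1 to compound 4 (0.87 log units; beyond the scatter), which shows that the same halogen on a different ring position can matter here. Nothing available explains this difference between the two bromophenyl groups.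

The compounds shown leave open whether this separation extends to other halogens, such as a fluorophenyl group. They also leave open how a pyridine ring in place of the phenyl, or a longer chain to the oxygen, would read.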